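The source may hold more compounds than are shown below. What is called first, only, known or untested is meant among the compounds shown, and "the series" means these compounds.

Three compounds of the series have been run in a functional assay on the whole organism (Abdomen, strain Swiss) for inhibition, with Mus musculus as the target, with stated times of 30 min, 10 min and 5 min, at a dose of 40 mg/kg by the oral route; a higher number here means a stronger effect of the compound at the dose given, a lower number a weaker effect. Compound 1 `CCc1nn(CCCN2CCN(c3ccc(C)cc3)CC2)c(=O)c(N)c1C(C)=O` gives 41%, and compound 2 `CCC(=O)c1c(C)nn(CCCN2CCN(c3ccc(C)cc3)CC2)c(=O)c1N` gives 29%. Compound 3 `CC(=O)c1cccn1CCCN1CCN(c2ccc(F)cc2)CC1` gives 38% in this assay, which places it second of the three numbers, with the gap to compound 1 and the gap to compound 2 both within the usual scatter. The next compound, compound 4 `CC(=O)c1cccn1CCCN1CCN(c2ccc(C)cc2)CC1`, differs from compound 3 by methyl in place of fluoro on an aromatic carbon. For the measured compounds named here, no measured pair in the set isolates this exchange, so no computed step is available for it. Compound 1, which carries the same 4-methylphenyl piperazine on a different core, gives 41%, a number close to that of compound 3. A step from compound 3 to compound 4 of no change at the digits printed from compound 3 to compound 4 (within the scatter) is therefore expected, that is, none beyond the scatter. Compound 4 is estimated at 38% in this assay, with a range from 26% to 50%.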

Compound 4, a percentage reported as inhibition, in the whole organism at one dose (the size of the read-out at that dose, not a potency): 9%
Compound 4: middle estimate off by 29 percentage points, on the high side; measured number below the stated range.
By their numbers in this assay, from the lowest: compound 4; then compounds 2, 3 and 1 (each within the scatter of the next, the first and the last beyond it).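

For the compounds shown here, exchanging 4-fluorophenyl for 4-methylphenyl gives a number 29 percentage points lower from compound 3 to compound 4 (beyond the scatter) in this assay, the first step that isolates a single place. At this position, on an aromatic carbon para to a large group, replacing one heavy atom with another is enough to move the read-out on this core. Nothing measured here accounts for the step. Going by these compounds, it remains open whether chloro, methoxy or an unsubstituted phenyl ring at this place would track compound 3 or compound 4. On these data alone, the same exchange on the core of compound 1 also remains open.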